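The source may hold more compounds than are shown below. What is called first, only, known or untested is meant among the compounds shown, and "the series" means these compounds.

Measured so far:
- compound 1, `Nc1ccccc1NC(=O)c1ccc(CSC(=S)N2CCN(c3ccccc3)CC2)cc1`: 87.4%
- compound 2, `N#Cc1ccc(N2CCN(C(=S)SCc3ccc(C(=O)Nc4ccccc4N)cc3)CC2)cc1`: 37.6%
- compound 3, `CN1CCN(C(=S)SCc2ccc(C(=O)Nc3ccccc3N)cc2)CC1`: 84.4%

All three share one core and differ only in the group on the amine nitrogen in the ring. In a functional assay on MGC-803 cells (Homo sapiens) for antiproliferative activity, read by CCK-8 assay, with a stated time of 72 h, tested at 8 uM (on this read-out lower numbers stand for a weaker effect and higher numbers for a stronger effect at the one concentration tested), compound 3 stands second highest of the three numbers; its nearest neighbour is compound 1, and the gap a number 3 percentage points lower from compound 1 to compound 3 (within the scatter) lies within the scatter, so the two cannot be told apart. The furthest is compound 2, and a number 46.8 percentage points higher from compound 2 to compound 3 (beyond the scatter) is a large step.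

Compound 4, `Nc1ccccc1NC(=O)c1ccc(CSC(=S)N2CCN(c3ccccc3F)CC2)cc1`, is not yet measured. Its change from compound 3 is 2-fluorophenyl in place of methyl on an amine nitrogen in a ring. For the measured compounds named here, two measured steps bear on it: a number 3 percentage points lower from compound 1 to compound 3 (within the scatter) shows that swapping methyl for phenyl changes nothing beyond the scatter, while a number 49.8 percentage points lower from compound 1 to compound 2 (beyond the scatter) shows that a cyano group on that phenyl lowers the read-out sharply. Going by the values given here, a 2-fluorophenyl is a phenyl carrying a fluorine rather than a cyano, and no measured pair shows what fluorine does here. Compound 4 is therefore expected to sit near compound 3, with a step of a number 8.4 percentage points lower from compound 3 to compound 4 (within the scatter), but with a wide range toward lower numbers. The estimate for compound 4 is 76%, between 45% and 92%.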

Compound 4, a percentage reported as inhibition, at one concentration (the size of the read-out at that concentration, not a potency): 86.4%
Estimate against measurement, compound 4: 10.4 percentage points below; low and high end bracket the measured number.
By their numbers in this assay, from the lowest: compound 2; then compounds 3, 4 and 1 (each within the scatter of the next).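

In this assay, putting a fluorine on the phenyl gives a number 1 percentage points lower from compound 1 to compound 4 (within the scatter), so 2-fluorophenyl and plain phenyl cannot be told apart at this ring nitrogen. Replacing methyl with 2-fluorophenyl gives a number 2 percentage points higher from compound 3 to compound 4 (within the scatter), so this larger ring-bearing group is also tolerated as well as methyl. Replacing 4-cyanophenyl with 2-fluorophenyl gives a number 48.8 percentage points higher from compound 2 to compound 4 (beyond the scatter), which shows that a substituted phenyl does not always carry a low number, and compound 2 is the one compound shown that goes against the otherwise level read-out.

No measurement offers a reason for the large gap between the 4-cyanophenyl and 2-fluorophenyl groups.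

On these data alone, since those two groups differ both in kind and in where they sit on the phenyl, it remains open whether a nitrile at the fluorine's place, or an amine or a carboxylic acid on the phenyl, would hold the read-out or lower it.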